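A few compounds are considered here, and "the series" means these few. Any claim that something is new, unique, unknown or untested is made for them only; others in the source may bear on it.

Measured so far in an in vitro functional assay on cells (Fibroblast) for agonist activity at Alpha-1B adrenergic receptor (Homo sapiens); on this read-out higher numbers stand for an effect only at larger amounts of compound and lower numbers for an effect already at smaller amounts:
Compound 1 `CCCn1ncnc1-c1ccccc1NCC1=NCCN1` gives 316 nM.
Compound 2 `CCCCn1ncnc1-c1ccccc1NCC1=NCCN1` gives 200 nM.
Compound 3 `CCn1nccc1-c1ccccc1NCC1=NCCN1` reaches only a limit of the assay, < 100000 nM.

Compound 2 differs from compound 1 by methyl in place of hydrogen on a saturated chain carbon, three bonds along the chain from an aromatic nitrogen, and this step gave a 1.6-fold lower number from compound 1 to compound 2 (0.20 log units; within the scatter). Compound 4 `CCCn1nccc1-c1ccccc1NCC1=NCCN1` is not yet measured; it differs from compound 3 by methyl in place of hydrogen on a saturated chain carbon, two bonds along the chain from an aromatic nitrogen, the same kind of change, though here the methyl enters two bonds along the chain from the aromatic nitrogen rather than three. The difference between the core of compound 3 and the core of compound 1 is not broken down here. For compound 3 only the limit of < 100000 nM in this assay, at which 1 of the 3 values shown sits, is available, so the step to compound 4 cannot be anchored to a measured number. Resting on compound 1 at 316 nM, the step from compound 3 to compound 4 is expected to be a step that the limit leaves unreadable from compound 3 to compound 4. Compound 4 is estimated at 2000 nM in this assay.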

Compound 4, half-maximal effective concentration: < 100000 nM
Compound 4: no number, only a limit (the forecaster's own chance of this, stated with the estimate: 25%); the middle value does not contradict the limit.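

Among the compounds shown here, compound 3 and compound 4 both give only a limit in this assay, so no step between them can be read. The compounds shown leave open whether methyl in place of hydrogen changes the read-out at all on the core of compound 3.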